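Exchanging fluoro for methoxy on compound 3

The compounds below may be only part of what the source reports. "The series", "measured", "known", "first", "only" and "open" are said of these compounds alone.

Compound 1 `COc1cccc(/C=C/C(=O)Nc2cc(OC)c(OC)c(OC)c2)c1` gives 43000 nM
Compound 2 `COc1cc(NC(=O)/C=C/c2cccc(OCc3ccccc3)c2)cc(OC)c1OC` gives 21700 nM
Compound 3 `C=C(Br)C(=O)Nc1cccc(/C=C/C(=O)Nc2ccc(F)cc2)c1` gives 4800 nM

In a functional assay on LoVo cells (Homo sapiens) for inhibition, read by MTT assay, with a stated time of 72 h (on this read-out higher numbers stand for weaker inhibition and lower numbers for stronger inhibition), compound 3 holds the lowest of the three numbers at 4800 nM, beyond the scatter from both other compounds. Compound 4 `C=C(Br)C(=O)Nc1cccc(/C=C/C(=O)Nc2ccc(OC)cc2)c1` keeps the rest of compound 3 and carries methoxy in place of fluoro on an aromatic carbon, para to a large group: methoxy in place of fluoro on an aromatic carbon. For the measured compounds named here, only one measured step is available, a 2.0-fold lower number from compound 1 to compound 2 (0.30 log units; within the scatter), and it lies within the scatter. That step sits at another place on a different core, so it bears only weakly on this exchange. Going by the values given here, no measured pair tests fluoro against methoxy. No step beyond the scatter is therefore expected in this assay, and neither direction is favoured. The estimated step is a 1.1-fold lower number from compound 3 to compound 4 (0.03 log units; within the scatter). In this assay compound 4 is estimated at 4500 nM within an expected range from 1800 nM to 11000 nM.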

Compound 4, half-maximal inhibitory concentration: 550 nM
Compound 4: middle estimate off by 8.2-fold (0.91 log units), on the high side, and the stated range ends above it.
By their numbers in this assay, from the lowest: compound 4; then compound 3; then compounds 2 and 1 (each within the scatter of the next).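

In this assay, the exchange of 4-fluorophenyl for 4-methoxyphenyl gives an 8.7-fold lower number from compound 3 to compound 4 (0.94 log units; beyond the scatter), so the read-out responds to the group on this aromatic carbon, para to a large group. The only earlier step, a 2.0-fold lower number from compound 1 to compound 2 (0.30 log units; within the scatter), lay within the scatter at another place on a different core, which makes this the first single change among the compounds shown to go beyond the scatter. Nothing available here explains why methoxy goes with the lower number on this core.

With only fluoro and methoxy shown at this position, it remains open whether a hydroxyl, an ethoxy or a dimethylamino group would give a lower or a higher number. On these data alone, whether the same exchange would give a similar step on the core of compound 1 also stays open.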